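A few compounds are considered here, and "the series" means these few. Any claim that something is new, unique, unknown or untested is made for them only; others in the source may bear on it.

Compound 1, with structure `NCc1ccccc1NC(=O)c1cnc2ccccc2c1`, stands at the low end of the three numbers at hand. In a physicochemical assay for solubility (on this read-out higher numbers stand for higher solubility and lower numbers for lower solubility), compound 1 gives 5 ug/mL, level with compound 3 `NCc1ccccc1NC(=O)c1cc2cc([N+](=O)[O-])ccc2o1`, which in this assay gives 5 ug/mL. Compound 2 `COC(=O)c1cccc(NC(=O)c2cc3cc([N+](=O)[O-])ccc3o2)c1` is the furthest of the set; in this assay compound 2 gives 25 ug/mL, a gap beyond the scatter, whereas the gap between compound 1 and compound 3 lies within it.

The step followed here goes from compound 1 to compound 4, whose structure is `CC(C)(C)OC(=O)NCc1ccccc1NC(=O)c1cnc2ccccc2c1`. The change is tert-butoxycarbonyl in place of hydrogen on an amine nitrogen whose other neighbour is a saturated chain carbon, read one bond further out as aminomethyl to ((tert-butoxycarbonyl)amino)methyl. Within the data shown here, no measured pair in the set shows this change, so no measured step guides the expectation.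

In this assay compound 4 is expected to come out somewhat lower than compound 1, the estimated step being a 2.5-fold lower number from compound 1 to compound 4 (0.40 log units; beyond the scatter), because compound 1 already stands at 5 ug/mL and the change adds seven heavy atoms without a donor. Compound 4 is therefore estimated at 2 ug/mL, with a range from 0.5 ug/mL to 8 ug/mL.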

Compound 4, solubility: 15 ug/mL
The estimate for compound 4 lay 7.5-fold (0.88 log units) below the measured number; the whole stated range lies below it.
By their numbers in this assay, from the lowest: compounds 1 and 3 (each within the scatter of the next); then compounds 4 and 2 (each within the scatter of the next).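

In this assay, tert-butoxycarbonyl in place of hydrogen on the amine nitrogen gives a 3.0-fold higher number from compound 1 to compound 4 (0.48 log units; beyond the scatter), a modest step but one beyond the scatter. Among these compounds, this is the first step measured at this position, and it shows that on the core of compound 1 the number does not fall when this hydrogen gives way to a group of 7 heavy atoms with no hydrogen-bond donors. Nothing in the data accounts for the direction of this step.

The compounds shown leave open whether a smaller group on the same nitrogen, such as acetyl or methyl, would give a step of the same direction and size. They also leave open whether tert-butoxycarbonyl would do the same on compound 3, which carries the free aminomethyl group and gives 5 ug/mL on another core.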